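The source may hold more compounds than are shown below. What is called first, only, known or untested is meant among the compounds shown, and "the series" means these compounds.

Measured compounds:
Compound 1, `CCC(CC)c1ccc2c(NCCCNCc3cc(F)ccc3OC)ccnc2c1`, gives 4200 nM in a physicochemical assay for solubility, with a stated time of 18 h, at pH 7.4; on this read-out lower numbers stand for lower solubility and higher numbers for higher solubility.
Compound 2, `COc1ccc(F)cc1CNCCCNc1ccnc2cc(Oc3ccc(C(C)(C)C)cc3)ccc12`, gives 14500 nM in this assay.
Compound 3, `CCC(CC)c1ccc2c(NCCCNCc3cccc(OC)c3O)ccnc2c1`, gives 4200 nM in this assay.

Of the compounds shown here, three have been measured so far, and they are connected by two single changes. Compound 3 differs from compound 1 only in the benzyl part: 2-hydroxy-3-methoxyphenyl in place of 5-fluoro-2-methoxyphenyl on a saturated chain carbon bound to an amine nitrogen. In this assay this exchange left the number where it was, no change at the digits printed from compound 1 to compound 3 (within the scatter), so compound 1 and compound 3 stand together at the lower end of the three numbers. Compound 2 differs from compound 1 at the core instead: 4-(tert-butyl)phenoxy in place of pentan-3-yl on an aromatic carbon. That exchange moved the read-out, a 3.5-fold higher number from compound 1 to compound 2 (0.54 log units; beyond the scatter).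

Compound 4, `COc1cccc(CNCCCNc2ccnc3cc(Oc4ccc(C(C)(C)C)cc4)ccc23)c1O`, has not yet been measured. Among the compounds with values here, it carries the same core as compound 2 and the same benzyl part as compound 3; it differs from compound 3 by 4-(tert-butyl)phenoxy in place of pentan-3-yl on an aromatic carbon, which is the same change as the one from compound 1 to compound 2, at the same place.

The expectation for compound 4 therefore rests on two things: the step seen for that change, a 3.5-fold higher number from compound 1 to compound 2 (0.54 log units; beyond the scatter), and the fact that compound 3 starts from the same point as compound 1, no change at the digits printed from compound 1 to compound 3 (within the scatter). Compound 4 is accordingly expected to move up from compound 3 by about a 3.3-fold higher number from compound 3 to compound 4 (0.52 log units; beyond the scatter). Compound 4 is estimated at 14000 nM, with a likely range from 6000 nM to 32000 nM.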

Compound 4, solubility: 14500 nM
Beside the measured number, compound 4's estimate is 1.0-fold (0.02 log units) below it, and the stated range covers the measured number.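

In this assay the exchange of pentan-3-yl for 4-(tert-butyl)phenoxy gave a 3.5-fold higher number from compound 3 to compound 4 (0.54 log units; beyond the scatter) when the benzyl part was 2-hydroxy-3-methoxyphenyl, and the same exchange with the 5-fluoro-2-methoxyphenyl benzyl part had given a 3.5-fold higher number from compound 1 to compound 2 (0.54 log units; beyond the scatter) so the printed size of the step is the same in both settings. The reverse view agrees, for the exchange of benzyl parts on the core bearing 4-(tert-butyl)phenoxy gave no change at the digits printed from compound 2 to compound 4 (within the scatter) and so left the number where it also stood unmoved on the core bearing pentan-3-yl. This shows that the two changes behaved independently within these four compounds, but it rests on a single pair of benzyl parts and a single pair of core groups, and it does not show that the step would carry over to any other partner.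

The compounds shown leave open whether the same step would appear with a carboxylic acid on the benzyl part, with an amine on the group that enters at the core, or with a longer chain joining the core to the benzyl part. Nothing given here explains why the numbers fall as they do.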